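A few compounds are considered here, and "the series" means these few. Any claim that something is new, unique, unknown or untested is made for them only; others in the source may bear on it.

Measured so far:
compound 1, `CC(C)N(Cc1cccc(OCCCCCC(=O)O)c1)C(=O)c1ccc(-c2ccsc2)cc1`: > 26000 nM
compound 2, `CCOC(=O)CCCCCOc1cccc(CN(C(=O)c2ccc(-c3ccc4ccccc4c3)cc2)C(C)C)c1`: > 26000 nM

Both values come from an ADME assay on BJ cells (Homo sapiens) for cytotoxicity, read by CellTiter-Glo and resazurin assay, with a stated time of 72 h; a higher number here means that more compound is needed for the effect, a lower number that less compound is needed. For compound 1 the value of > 26000 nM is a limit of the assay, not a number. For compound 2 the value of > 26000 nM is likewise a limit rather than a number. Within the data shown here, compound 2 therefore stands only at a limit, and the one further value is a limit as well: the limit of > 26000 nM in this assay, at which 2 of the 2 values shown sit. Among the measured compounds shown here, no step between measured compounds can be drawn from this.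

Compound 3, `CCOC(=O)CCCCCOc1cccc(CN(C(=O)c2ccc(-c3ccc(C(C)=O)s3)cc2)C(C)C)c1`, is still to be measured in this assay. It differs from compound 2 in one place: 5-acetylthiophen-2-yl in place of naphthalen-2-yl on an aromatic carbon. With both measured values sitting at the same limit, no step beyond the scatter is expected in either direction, and the reading for compound 3 is expected most likely to return as a limit once more. The estimate for compound 3 is 30000 nM, with a range of 12000 nM to 80000 nM. The expected step is a step that the limit leaves unreadable from compound 2 to compound 3.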

Compound 3, half-maximal effective concentration: > 26000 nM
Compound 3: only a limit was reported; the forecaster's own chance of this, stated with the estimate: 75%; the middle value does not contradict the limit.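

No step can be read in this assay between compound 2 and compound 3: both readings are limits, not numbers. The compounds shown leave open whether 5-acetylthiophen-2-yl and naphthalen-2-yl differ at all in this assay, and where any of these compounds would give an actual number.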